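Methoxy added onto the ring-methylated analogue

The compounds below may be only part of what the source reports. "The series", "measured", "known", "first", "only" and "open" are said of these compounds alone.

Compound 3 `Cn1ccc2c(Oc3ccc(NC(=O)c4cc5cccnc5n(-c5ccccc5)c4=O)cc3F)ccnc21` stands second highest of the three numbers in a functional assay on A549 cells (Homo sapiens) for antiproliferative activity, read by MTT assay, with a stated time of 72 h; on this read-out higher numbers stand for weaker inhibition and lower numbers for stronger inhibition: compound 3 gives 430 nM, nearest to compound 2 `COc1ccc(-n2c(=O)c(C(=O)Nc3ccc(Oc4ccnc5[nH]ccc45)c(F)c3)cc3cccnc32)cc1`, which gives 610 nM, a gap within the scatter, and furthest from compound 1 `O=C(Nc1ccc(Oc2ccnc3[nH]ccc23)c(F)c1)c1cc2cccnc2n(-c2ccccc2)c1=O`, which gives 190 nM. The step of a 2.3-fold higher number from compound 1 to compound 3 (0.35 log units; beyond the scatter) came with methyl in place of hydrogen on an aromatic nitrogen.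

Compound 4 `COc1ccc(-n2c(=O)c(C(=O)Nc3ccc(Oc4ccnc5c4ccn5C)c(F)c3)cc3cccnc32)cc1` differs from compound 3 by methoxy in place of hydrogen on an aromatic carbon. For the measured compounds named here, one measured step bears directly on this change, a 3.2-fold higher number from compound 1 to compound 2 (0.51 log units; beyond the scatter), the same methoxy entering on the unmethylated parent. Going by the values given here, nothing among the measured compounds shows how the methoxy and the methylated nitrogen behave together, so the only guide is to carry that step over unchanged. Expected for compound 4 is therefore a higher number in this assay by about the same margin, a 3.3-fold higher number from compound 3 to compound 4 (0.51 log units; beyond the scatter), a modest step beyond the scatter. The estimate for compound 4 in this assay is 1400 nM, with a range from 600 nM to 3500 nM.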

Compound 4, half-maximal inhibitory concentration: 2750 nM
Compound 4: middle estimate off by 2.0-fold (0.29 log units), on the low side; low and high end bracket the measured number.
By their numbers in this assay, from the lowest: compound 1; then compounds 3 and 2 (each within the scatter of the next); then compound 4.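

In this assay the change from phenyl to 4-methoxyphenyl, on an aromatic carbon para to a large group, now has a second reading on the core with the methylated nitrogen, a 6.4-fold higher number from compound 3 to compound 4 (0.81 log units; beyond the scatter), and the number rises on both cores, so this rise is not confined to the unmethylated parent: the same change on two cores in this assay, a 3.2-fold higher number (0.51 log units; beyond the scatter) from compound 1 to compound 2 and a 6.4-fold higher number (0.81 log units; beyond the scatter) from compound 3 to compound 4, 2.0-fold (0.30 log units) apart, within the scatter of two such steps

The methyl on the aromatic nitrogen also repeats its direction on the methoxy-bearing core, a 4.5-fold higher number from compound 2 to compound 4 (0.65 log units; beyond the scatter), so that change too now has two readings: the same change on two cores in this assay, a 2.3-fold higher number (0.35 log units; beyond the scatter) from compound 1 to compound 3 and a 4.5-fold higher number (0.65 log units; beyond the scatter) from compound 2 to compound 4, 2.0-fold (0.30 log units) apart, within the scatter of two such steps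

With both gaps inside the scatter, these four compounds read as two changes that each raise the number, and they give no firm sign that either change alters the size of the other.

At the para place the compounds shown hold only hydrogen and methoxy, so it stays open whether the rise belongs to methoxy itself or would also follow with a hydroxyl, an amine, a carboxylic acid or a longer alkoxy chain there. On the nitrogen only hydrogen and methyl appear, and an ethyl or a longer chain carrying an amine would test how far that step extends.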